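Series notes: trimethoxyphenyl in place of hydroxyphenyl

A few compounds are considered here, and "the series" means these few. Any claim that something is new, unique, unknown or untested is made for them only; others in the source may bear on it.

Measured so far:
Compound 1 `Cc1cc(O)c(C2=NN(c3ccc(S(N)(=O)=O)cc3)C(c3ccccc3O)C2)cc1Cl` gives 5500 nM in a functional assay on HCT-116 cells (Homo sapiens) for antiproliferative activity, with a stated time of 48 h; on this read-out higher numbers stand for lower toxicity in this test and lower numbers for higher toxicity in this test.
Compound 2 `Cc1cc(O)c(C2=NN(c3ccc(S(N)(=O)=O)cc3)C(c3ccccc3Cl)C2)cc1Cl` gives 5610 nM in this assay.

Compound 1 and compound 2 lie within the scatter of each other: a 1.0-fold higher number from compound 1 to compound 2 (0.01 log units; within the scatter). Compound 3 `COc1ccc(C2CC(c3cc(Cl)c(C)cc3O)=NN2c2ccc(S(N)(=O)=O)cc2)c(OC)c1OC` carries 2,3,4-trimethoxyphenyl in place of 2-hydroxyphenyl on a saturated ring carbon. Going by the values given here, the only measured step at the same saturated ring carbon is the one from compound 1 to compound 2, which stayed within the scatter; no measured step covers a trimethoxyphenyl group, so the expectation in this assay is no change beyond the scatter, with wide uncertainty. Compound 3 is therefore expected at 5500 nM, with a range from 1800 nM to 17000 nM. This estimate means an expected step of no change at the digits printed from compound 1 to compound 3 (within the scatter).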

Compound 3, concentration lethal to 50% of the cells: 5460 nM
Compound 3: the middle estimate sits 1.0-fold (0.00 log units) above what was measured; the measured number falls inside the stated range.
By their numbers in this assay, from the lowest: compounds 3, 1 and 2 (each within the scatter of the next).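

In this assay, the saturated ring carbon accepts 2,3,4-trimethoxyphenyl in place of 2-hydroxyphenyl (a 1.0-fold lower number from compound 1 to compound 3 (0.00 log units; within the scatter)) and in place of 2-chlorophenyl (a 1.0-fold lower number from compound 2 to compound 3 (0.01 log units; within the scatter)). Unlike the chloro-for-hydroxy exchange, this change enlarges the group and replaces its hydrogen-bond donor with methoxy oxygens, yet the number stays within the scatter. Nothing shown explains this insensitivity. 

The compounds leave open whether an amine or a carboxylic acid on this phenyl ring would move the number beyond the scatter. Replacing the 4-sulfamoylphenyl group also remains untested among these compounds.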